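Mirror-Image Ureas Under the Whole-Organism Read-Out

A few compounds are considered here, and "the series" means these few. Any claim that something is new, unique, unknown or untested is made for them only; others in the source may bear on it.

Two aryl ureas have so far been examined in an ADME assay on the whole organism with Oryza sativa as the target, tested at 0.1 uM; on this read-out lower numbers stand for a stronger effect and higher numbers for a weaker effect at the one concentration tested. Compound 1 `COc1cccc(NC(=O)N[C@@H](C)c2ccccc2)c1` gives 101% in this assay, a read-out that signals essentially no effect at the concentration used. Compound 2 `C[C@@H](NC(=O)Nc1cccc(F)c1)c1ccccc1` gives 99% in this assay. Of the two numbers shown, that of compound 2 is the smaller, yet its distance from compound 1 lies within the usual scatter, so the two compounds cannot be told apart on this read-out and neither can be called the more active.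

Compound 3 `C[C@H](NC(=O)Nc1cccc(F)c1)c1ccccc1` is the counterpart of compound 2 with the opposite configuration: the two compounds have the same atoms and bonds and differ only in configuration as drawn: 1 of 1 stereo elements differ; a stereocentre at a saturated chain carbon is drawn R in compound 2 and S in compound 3. No measured pair among these compounds shows what such a change does in this assay, so no step can be drawn from the data. Because compound 2 already sits at 99%, close to the top of the scale, the step from compound 2 to compound 3 is expected to be none beyond the scatter. Compound 3 is therefore estimated at 98%, with a range from 86% to 106%, expected to be a number 1 percentage points lower from compound 2 to compound 3 (within the scatter).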

Compound 3, a percentage reported as activity, at one concentration (the size of the read-out at that concentration, not a potency): 97%
Compound 3: middle estimate off by 1 percentage points, on the high side; low and high end bracket the measured number.
By their numbers in this assay, from the lowest: compounds 3, 2 and 1 (each within the scatter of the next).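

Inverting the stereocentre at the saturated chain carbon gives, in this assay, a number 2 percentage points lower from compound 2 to compound 3 (within the scatter), so at this position the configuration as drawn leaves no difference that can be told from the scatter. Fluoro in place of methoxy on an aromatic carbon likewise gives a number 4 percentage points lower from compound 1 to compound 3 (within the scatter), which adds a second change that this read-out does not resolve. The first comparison is the cleanest available in the set, with nothing but the stereocentre altered: the fact that compounds 2 and 3 differ only in the configuration as drawn

From the compounds shown here alone, what remains open is whether this assay can separate compounds at all, as all three numbers lie within the scatter of one another at the single concentration tested, and a pair of configurations that cannot be told apart here might still be told apart on a read-out that moves. Going by these compounds, it is equally open whether an amine or a carboxylic acid in place of fluoro on that aromatic carbon, or a longer chain at the stereocentre, would shift the number beyond the scatter, and whether the configuration would matter in such a compound.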